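This account rests on a few compounds, and the source may have more. Where it says the series, first, only, none or still open, it means among the compounds named here.

The series shares one core, seen in compound 1 `CCN(CC)S(=O)(=O)c1ccc(S(=O)(=O)N2CCC[C@@H](C(=O)N(C)C(C)C)C2)cc1`, which in a functional assay on BXPC-3 cells (Homo sapiens) for inhibition, read by MTT assay, with a stated time of 7 days (a lower number here means a stronger inhibitor, a higher number a weaker inhibitor), gives 7700 nM. Compound 2 `CCN(CC)S(=O)(=O)c1ccc(S(=O)(=O)N2CCC[C@@H](C(=O)NC3CN(C(=O)C4CC4)C3)C2)cc1` gives 18500 nM in this assay, and compound 3 `CCN(CC)S(=O)(=O)c1ccc(S(=O)(=O)N2CCC[C@@H](C(=O)NC)C2)cc1` gives 13800 nM. Compound 3 thus stands second highest of the three numbers; the gap a 1.3-fold lower number from compound 2 to compound 3 (0.13 log units; within the scatter) lies within the scatter, as does the gap a 1.8-fold higher number from compound 1 to compound 3 (0.25 log units; within the scatter). Compound 4 `CCN(CC)S(=O)(=O)c1ccc(S(=O)(=O)N2CCC[C@@H](C(=O)NC3CN(S(C)(=O)=O)C3)C2)cc1` differs from compound 3 by 1-(methylsulfonyl)azetidin-3-yl in place of methyl on an amide-type nitrogen. The measured step that bears most on this change is a 1.3-fold lower number from compound 2 to compound 3 (0.13 log units; within the scatter), where 1-(cyclopropylcarbonyl)azetidin-3-yl was exchanged for methyl on the same amide-type nitrogen with no shift beyond the scatter; the step of a 2.4-fold higher number from compound 1 to compound 2 (0.38 log units; beyond the scatter) was modest. On that basis no step beyond the scatter is expected in this assay, though a modest rise in the number, as seen for compound 2, remains possible. For compound 4 the expected step is a 1.2-fold higher number from compound 3 to compound 4 (0.06 log units; within the scatter). Compound 4 is therefore estimated at 16000 nM, with a range from 7000 nM to 40000 nM.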

Compound 4, half-maximal inhibitory concentration: 7400 nM
Beside the measured number, compound 4's estimate is 2.2-fold (0.33 log units) above it, and the stated range covers the measured number.
By their numbers in this assay, from the lowest: compounds 4, 1, 3 and 2 (each within the scatter of the next, the first and the last beyond it).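

In this assay the exchange on the amide-type nitrogen gives a 1.9-fold lower number from compound 3 to compound 4 (0.27 log units; within the scatter) and so stays within the scatter, despite the larger 1-(methylsulfonyl)azetidin-3-yl entering in place of methyl, while the exchange on the carbonyl carbon gives a 1.0-fold lower number from compound 1 to compound 4 (0.02 log units; within the scatter) and likewise separates nothing. New here is a change at the amine nitrogen in the ring: methylsulfonyl in place of cyclopropylcarbonyl gives a 2.5-fold lower number from compound 2 to compound 4 (0.40 log units; beyond the scatter) as a modest step beyond the scatter, the only step shown at that nitrogen. No evidence is available to account for this step.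

The compounds shown leave open how a free amine, an acetyl or an ethyl group on that ring nitrogen would compare. They also leave open whether a carboxylic acid-bearing chain on the amide-type nitrogen would move the number beyond the scatter.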